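This account rests on a few compounds, and the source may have more. Where it says the series, first, only, none or still open, it means among the compounds named here.

In an ADME assay on L02 cells (Homo sapiens) for antiproliferative activity, read by MTT assay, with a stated time of 48 h (a lower number here means a stronger inhibitor, a higher number a weaker inhibitor), compound 1, `CCn1c(C(=O)Nc2cccc(C(F)(F)F)c2)ccc1C(CC)(CC)c1ccc(OCCC(O)(CC)CC)c(C)c1`, reads > 50000 nM, which is a limit of the assay. For the measured compounds named here, compound 2, `CCC(C)C(NC(=O)c1ccc(C(CC)(CC)c2ccc(OCCC(O)(CC)CC)c(C)c2)n1CC)C(=O)O`, gives 9990 nM, the only true number so far. Going by the values given here, the sole measured step, an at least 5.0-fold lower number from compound 1 to compound 2 (0.69 log units; beyond the scatter), swapped a whole substituent, so it bears only loosely on what follows and does not isolate the carboxy group. Compound 3, `CCC(C)C(CO)NC(=O)c1ccc(C(CC)(CC)c2ccc(OCCC(O)(CC)CC)c(C)c2)n1CC`, differs from compound 2 by hydroxymethyl in place of carboxy on a saturated chain carbon bound to an amide-type nitrogen and a saturated chain carbon, with hydroxymethyl in place of carboxy on a saturated chain carbon. The expected change is modest, a 1.5-fold higher number from compound 2 to compound 3 (0.18 log units; within the scatter), toward weaker inhibition. Compound 3 is estimated at 15000 nM, with an expected range of 5000 nM to 45000 nM.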

Compound 3, half-maximal inhibitory concentration: > 50000 nM
Compound 3: only a limit was reported; the forecaster's own chance of this, stated with the estimate: 20%; middle value at least 3.3-fold (0.52 log units) from the limit.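

Hydroxymethyl in place of carboxy on a saturated chain carbon bound to an amide-type nitrogen and a saturated chain carbon gives an at least 5.0-fold higher number from compound 2 to compound 3 (0.69 log units; beyond the scatter) in this assay, so this change isolates the carboxy group, which the earlier step could not do. The reading for compound 3 is a limit, so the full size of this step stays unknown: the limit of > 50000 nM in this assay, at which 2 of the 3 values shown sit.

The step from compound 1 to compound 3 cannot be read. On these data alone, whether a methyl ester or a primary amide in place of carboxy would keep the reading of compound 2 remains open.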